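Methyl scan on the benzyloxy aryl series

This account rests on a few compounds, and the source may have more. Where it says the series, first, only, none or still open, it means among the compounds named here.

Three compounds share one core and differ only in the substitution of the terminal aryl ring. Compound 1 `Cc1cccc(COc2ccc(-c3cc(CN4CCN(Cc5ccc(C(F)(F)F)cc5)CC4)no3)cc2)c1` gives 4000 nM in a functional assay on MCF7 cells (Homo sapiens) for antiproliferative activity, read by sulforhodamine B assay, with a stated time of 72 h; on this read-out higher numbers stand for weaker inhibition and lower numbers for stronger inhibition. Compound 2 `Cc1cc(C)cc(COc2ccc(-c3cc(CN4CCN(Cc5ccc(C(F)(F)F)cc5)CC4)no3)cc2)c1` gives 1600 nM in this assay, and compound 3 `N#Cc1cccc(COc2ccc(-c3cc(CN4CCN(Cc5ccc(C(F)(F)F)cc5)CC4)no3)cc2)c1` gives 800 nM in this assay.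

The steps among them are modest. The change methyl in place of hydrogen on an aromatic carbon gave a 2.5-fold lower number from compound 1 to compound 2 (0.40 log units; beyond the scatter). The change cyano in place of methyl on an aromatic carbon gave a 5.0-fold lower number from compound 1 to compound 3 (0.70 log units; beyond the scatter). Between compound 2 and compound 3 the difference is a 2.0-fold lower number from compound 2 to compound 3 (0.30 log units; within the scatter), so these two cannot be ranked against each other.

Compound 4 `Cc1cc(OCc2cccc(C#N)c2)ccc1-c1cc(CN2CCN(Cc3ccc(C(F)(F)F)cc3)CC2)no1` is not yet measured. Relative to compound 3 the difference is methyl in place of hydrogen on an aromatic carbon. This is the same kind of change as that from compound 1 to compound 2, but not the same: in compound 4 the entering methyl sits ortho to a large group and meta to a (3-cyanobenzyl)oxy group, whereas in compound 2 it sits meta to a large group and meta to a methyl group. The two cores differ by cyano in place of methyl on an aromatic carbon.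

Given that a single added methyl produced a 2.5-fold lower number from compound 1 to compound 2 (0.40 log units; beyond the scatter), a step of about the same kind and size is expected here, with some allowance for the different surroundings; the expected step is a 1.6-fold lower number from compound 3 to compound 4 (0.20 log units; within the scatter). Compound 4 is therefore estimated at 500 nM in this assay, with a likely range from 200 nM to 1300 nM.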

Compound 4, half-maximal inhibitory concentration: 400 nM
Beside the measured number, compound 4's estimate is 1.3-fold (0.10 log units) above it; low and high end bracket the measured number.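

In this assay, methyl in place of hydrogen on an aromatic carbon, ortho to a large group and meta to a (3-cyanobenzyl)oxy group, gave a 2.0-fold lower number from compound 3 to compound 4 (0.30 log units; within the scatter), so these two compounds cannot be ranked against each other. Set beside the earlier methyl step, the size of the change shows no detectable difference between the two cores: the same change on two cores in this assay, a 2.5-fold lower number (0.40 log units; beyond the scatter) from compound 1 to compound 2 and a 2.0-fold lower number (0.30 log units; within the scatter) from compound 3 to compound 4, 1.3-fold (0.10 log units) apart, within the scatter of two such steps. Going by these compounds alone, this agreement rests on only two pairs, of which only the earlier step lies beyond the scatter, and the methyl sits in different surroundings on each core, so the data neither show that the change lowers the number on every core nor separate the effect of its place from that of the core.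

Still open, going by these compounds, is whether another small group on the same aromatic carbon, such as fluorine, chlorine, methoxy or ethyl, would give a step of similar size on the core of compound 3. Also open, on these data alone, is how a primary amine or a carboxylic acid on the terminal aryl ring would compare with the nitrile of compound 3 and compound 4.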